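A few compounds are considered here, and "the series" means these few. Any claim that something is new, unique, unknown or untested is made for them only; others in the source may bear on it.

Of the compounds shown here, two have so far been tested in a functional assay on the whole organism (blood, strain Wistar-Okamoto) with Rattus norvegicus as the target, with a stated time of 5 days; a lower number here means that less compound is needed, a higher number that more compound is needed for the effect. Compound 1, `CC(C)(C)CC(C)(C)/N=C(\NC#N)Nc1cccnc1`, gives 50 mg/kg in this assay. Compound 2, `CC(C)(C)C(C)(C)/N=C(\NC#N)Nc1ccncc1`, gives 20 mg/kg in this assay, which is the lowest of the two numbers, and the gap to compound 1, its nearest neighbour, lies beyond the usual scatter of repeated measurements.

The next compound to be measured is compound 3, `CC(C)(C)CC(C)(C)/N=C(\NC#N)Nc1ccncc1`. It differs from compound 2 in one place: neopentyl in place of tert-butyl on a saturated chain carbon bound to a double-bonded nitrogen and two saturated chain carbons. The neopentyl group that enters is the same group carried by compound 1, so compound 3 combines that group with the rest of compound 2. Within the data shown here, no pair of measured compounds differs in just this one place, so the effect of this change on its own has not been seen directly.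

Compound 2 gave 20 mg/kg and compound 1, which carries the neopentyl group, gave 50 mg/kg, so a small rise in dose is expected for compound 3, likely close to the scatter, with an expected step of a 1.5-fold higher number from compound 2 to compound 3 (0.18 log units; within the scatter). The estimate for compound 3 in this assay is 30 mg/kg, within a range from 12 mg/kg to 80 mg/kg.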

Compound 3, minimum effective dose: 50 mg/kg
Beside the measured number, compound 3's estimate is 1.7-fold (0.22 log units) below it; low and high end bracket the measured number.
By their numbers in this assay, from the lowest: compound 2; then compounds 1 and 3 (each within the scatter of the next).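

In this assay, neopentyl in place of tert-butyl on a saturated chain carbon bound to a double-bonded nitrogen and two saturated chain carbons can now be read on its own: it gives a 2.5-fold higher number from compound 2 to compound 3 (0.40 log units; beyond the scatter) and so shows that the dose needed depends on which of these two groups stands at this place. The other single change can be read as well, since pyridin-4-yl in place of pyridin-3-yl on an amine nitrogen gives no change at the digits printed from compound 1 to compound 3 (within the scatter) with neopentyl present. The earlier gap between compound 1 and compound 2 spanned both changes at once, and now that they are separated, only the swap of tert-butyl for neopentyl carries a step beyond the scatter.

On these data alone, whether the change between pyridin-3-yl and pyridin-4-yl would also leave the number unmoved with tert-butyl in place remains open, as does the result of putting an isopropyl or cyclohexyl group at the same place. No measurement shown here gives a reason for the step between the two chain groups.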